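A few compounds are considered here, and "the series" means these few. Any claim that something is new, unique, unknown or untested is made for them only; others in the source may bear on it.

Measured so far, in a functional assay on NCI-H522 cells (Homo sapiens) for inhibition, read by sulforhodamine B assay, with a stated time of 48 h; a lower number here means a stronger inhibitor of growth, a higher number a weaker inhibitor of growth:
- compound 1 `COc1cc2cc(Oc3ccc(NC(=O)Nc4cccc(C(F)(F)F)c4)cc3)c(C)nc2cc1OC`: 1320 nM
- compound 2 `COc1cc2cc(Oc3ccc(NC(=O)Nc4ccc(Cl)c(C(F)(F)F)c4)cc3)c(C)nc2cc1OC`: 773 nM

For the measured compounds named here, compound 2 holds the lower of the two numbers in this assay, but its only neighbour, compound 1, sits at 1320 nM, and the step of a 1.7-fold lower number from compound 1 to compound 2 (0.23 log units; within the scatter) stays within the scatter, so the two compounds cannot be told apart on these data.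

Compound 3 `COc1cc2cc(Oc3ccc(NC(=O)Nc4ccc(Cl)c(Cl)c4)cc3)c(C)nc2cc1OC` has not been measured. It differs from compound 2 by chloro in place of trifluoromethyl on an aromatic carbon. Going by the values given here, the only measured step, a 1.7-fold lower number from compound 1 to compound 2 (0.23 log units; within the scatter), concerns a different position and a different exchange (hydrogen to chloro), and it was itself within the scatter; it therefore offers no direct guide to the trifluoromethyl-to-chloro exchange. Among the compounds with values here, with no step that bears on the change, the expectation rests on the general observation that the two compounds so far lie close together. The estimated step of a 1.2-fold higher number from compound 2 to compound 3 (0.07 log units; within the scatter) is expected to stay within the scatter. Compound 3 is estimated at 900 nM in this assay, with a range of 400 nM to 2200 nM.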

Compound 3, concentration for 50% growth inhibition: 1740 nM
The estimate for compound 3 lay 1.9-fold (0.29 log units) below the measured number, within the range that was stated.
By their numbers in this assay, from the lowest: compounds 2, 1 and 3 (each within the scatter of the next, the first and the last beyond it).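

In this assay, for the compounds shown here, chloro in place of trifluoromethyl, at the position ortho to a chloro group, gives a 2.3-fold higher number from compound 2 to compound 3 (0.35 log units; beyond the scatter), the only step so far that lies beyond the scatter, though it is modest. This position therefore does register a change of group, and with the chloro group held constant, the 4-chloro-3-(trifluoromethyl)phenyl of compound 2 reads better than the 3,4-dichlorophenyl of compound 3. The difference does not extend to the comparison with the singly substituted ring, since a 1.3-fold higher number from compound 1 to compound 3 (0.12 log units; within the scatter) leaves those two compounds indistinguishable, and nothing available explains why the exchange at this position moves the number.

Going by these compounds, two groups at one position, each with the chloro group present, define no trend, so it remains open how a methyl, a methoxy, a nitrile or an amine in the same place would read against trifluoromethyl and chloro. On these data alone, it also remains open whether the step from chloro to trifluoromethyl would keep its size with a different group, such as fluoro or methoxy, in place of the partnering chloro.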